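Adding one more methyl to the aryl side chain

The compounds below may be only part of what the source reports. "The series", "measured", "known", "first", "only" and "open" are said of these compounds alone.

Measured compounds:
- compound 1, `CCc1ccc(NC(=O)N[C@H](C)c2ccccc2)cc1`: 47%
- compound 2, `CC(C)c1ccc(NC(=O)N[C@H](C)c2ccccc2)cc1`: 79%

Both compounds share one core; they differ only in the alkyl group on the aromatic ring. In an ADME assay on the whole organism with Oryza sativa as the target, tested at 1 uM (a lower number here means a stronger effect, a higher number a weaker effect of the compound at the concentration tested), compound 1 gives 47%. In this assay, within the data shown here, compound 2 gives 79%, the highest of the two numbers measured, and the only other number, that of compound 1, is well separated from it: a number 32 percentage points higher from compound 1 to compound 2 (beyond the scatter).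

The next compound, compound 3 `C[C@@H](NC(=O)Nc1ccc(C(C)(C)C)cc1)c1ccccc1`, takes the series one step further. Its difference from compound 2 is methyl in place of hydrogen on a saturated chain carbon bound to an aromatic carbon and two saturated chain carbons.

Among the measured compounds shown here, only one measured step is of the same kind, and it is large: a number 32 percentage points higher from compound 1 to compound 2 (beyond the scatter). If the added methyl acts as the previous one did, the number for compound 3 should rise again, although the number cannot go far beyond where compound 2 already stands. For compound 3 the expected step is therefore upward, a number 9 percentage points higher from compound 2 to compound 3 (within the scatter), but smaller than the measured one. The estimate for compound 3 in this assay is 88%, with a range from 70% to 100%.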

Compound 3, a percentage reported as activity, at one concentration (the size of the read-out at that concentration, not a potency): 88%
Estimate against measurement, compound 3: no gap at the digits printed; the measured number falls inside the stated range.
By their numbers in this assay, from the lowest: compound 1; then compounds 2 and 3 (each within the scatter of the next).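

In this assay, isopropyl to tert-butyl gives a number 9 percentage points higher from compound 2 to compound 3 (within the scatter) and so leaves compound 2 and compound 3 indistinguishable, unlike the earlier methyl addition on the same side chain, which gave a number 32 percentage points higher from compound 1 to compound 2 (beyond the scatter). The two ends of the series remain clearly apart: tert-butyl in place of ethyl on an aromatic carbon gives a number 41 percentage points higher from compound 1 to compound 3 (beyond the scatter), so among these three compounds only compound 1, the ethyl member, stands apart from the others, and the third methyl adds no separation that can be read. Nothing available here offers an explanation for either the large step or the lack of a readable one.

Going by these compounds, the three compounds cover only ethyl, isopropyl and tert-butyl, so it remains open how a plain methyl group, a longer chain such as n-butyl, or a cyclopropyl ring on the same aromatic carbon would compare. On these data alone, it is also open whether a group of a different kind there, such as trifluoromethyl or methoxy, would fall with compound 1 or with compound 2 and compound 3.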